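Replacing 2-carboxycyclopropyl with 2-carboxypropyl in compound 1

The compounds below may be only part of what the source reports. "The series", "measured", "known", "first", "only" and "open" are said of these compounds alone.

Among the measured compounds shown here, in an in vivo ADME assay on the whole organism (strain Sprague-Dawley) for pharmacokinetics, with Rattus norvegicus as the target, at a dose of 2 mg/kg by the oral route (on this read-out higher numbers stand for higher oral bioavailability and lower numbers for lower oral bioavailability), compound 1 (`Cc1cc([C@@H]2C[C@H]2C(=O)O)ccc1-c1noc(-c2ccc(OC(C)C)c(C(F)(F)F)c2)n1`) gives 88% as its only number, and a further entry for it carries no single number. Compound 2 (`Cc1cc([C@@H]2C[C@H]2C(=O)O)ccc1-c1noc(-c2ccc(OC(C)C)c(C#N)c2)n1`) gives 84%; 90% (2 entries) in this assay and lies within the usual scatter of compound 1 on this read-out. Compound 3 (`Cc1cc(CC(C)C(=O)O)ccc1-c1noc(-c2ccc(OC(C)C)c(C(F)(F)F)c2)n1`) keeps the core of compound 1 but carries 2-carboxypropyl in place of 2-carboxycyclopropyl on an aromatic carbon. For the measured compounds named here, no measured step covers this change, so any expectation in this assay remains loose. A moderate fall slightly beyond the scatter is expected, and the estimated move is a number 16 percentage points lower from compound 1 to compound 3 (beyond the scatter) on this read-out. Compound 3 is estimated at 72% in this assay with an expected range from 45% to 90% for this measurement.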

Compound 3, oral bioavailability: 82%
Compound 3: middle estimate off by 10 percentage points, on the low side; the range from low to high includes it.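

In this assay, 2-carboxypropyl in place of 2-carboxycyclopropyl on this aromatic carbon gives a number 6 percentage points lower from compound 1 to compound 3 (within the scatter). For this pair, then, oral bioavailability does not depend measurably on the three-membered ring or on the 2 defined stereocentres that leave with it, and the open chain with the same count of heavy atoms serves at this position. The step is of a size seen between repeat measurements of a single compound: the several entries of compound 2 in this assay, 84%; 90% (2 entries).

On these data alone, whether the same replacement holds on the nitrile-bearing compound 2 remains open, as this is a single pair on the trifluoromethyl compound. Also open, as far as these compounds go, is how this read-out responds to a longer chain between the aromatic carbon and the acid, or to a primary amide or a tetrazole in place of the carboxylic acid.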